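The compounds below may be only part of what the source reports. "The series", "measured", "known", "first", "only" and "open" are said of these compounds alone.

Values in a functional assay, read by spectrophotometry, with a stated time of 6 min; a higher number here means a weaker inhibitor, a lower number a stronger inhibitor:
- compound 1 `CCOc1cc(OC)c(Br)cc1C(C)=O`: 36000000 nM
- compound 2 `CCCCOc1cc(OC)c(Br)cc1C(C)=O`: 34100000 nM
- compound 3 `CCCCOc1cc(OC)ccc1C(C)=O`: 36300000 nM

Compound 3 stands level with the other two, since all three values lie within the usual scatter of repeated measurements. Compound 4 `CCCCCCCCCCCCOc1cc(OC)ccc1C(C)=O` keeps the core of compound 3 and lengthens its chain: octyl in place of hydrogen on a saturated chain carbon, four bonds along the chain from an oxygen on an aromatic ring. In words, this is octyl in place of hydrogen on a saturated chain carbon, four bonds along the chain from an oxygen on an aromatic ring.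

Among the measured compounds shown here, the closest precedent is also a chain extension, a 1.1-fold lower number from compound 1 to compound 2 (0.02 log units; within the scatter). It adds only ethyl, at a different chain carbon, so it is a limited guide to a much longer addition. The other measured change, a 1.1-fold higher number from compound 2 to compound 3 (0.03 log units; within the scatter), concerns bromo rather than the chain, and it also left the number in place. Neither gives a reason to expect a real shift, although the data do not cover a chain this long. The expected change is a 1.5-fold lower number from compound 3 to compound 4 (0.16 log units; within the scatter), which is no step beyond the scatter. For compound 4 the estimated value is 25000000 nM, with an expected range from 6000000 nM to 45000000 nM.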

Compound 4, half-maximal inhibitory concentration: 40700000 nM
Compound 4: the middle estimate sits 1.6-fold (0.21 log units) below what was measured; the range from low to high includes it.
By their numbers in this assay, from the lowest: compounds 2, 1, 3 and 4 (each within the scatter of the next).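

Until now, the only chain extension on record was a small ethyl addition at a different chain carbon. In this assay, the step with octyl, which enters with 8 heavy atoms, all carbon, is a 1.1-fold higher number from compound 3 to compound 4 (0.05 log units; within the scatter), so even this far larger addition at this chain carbon does not separate the two compounds. None of the information available explains why the chain's size makes so little difference here.

Among the compounds shown here, all the groups added at this place so far are plain carbon chains, so it remains open whether an amine or a carboxylic acid at the same carbon would move the number beyond the scatter. A phenyl ring there, or a chain longer than octyl, is equally untested by the compounds shown.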